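Trading Methylcarbamoyl for Hydroxycarbamoyl on a Shorter Chain

This account rests on a few compounds, and the source may have more. Where it says the series, first, only, none or still open, it means among the compounds named here.

Three compounds have been measured in a functional assay on HEL cells (Homo sapiens) for inhibition; on this read-out higher numbers stand for weaker inhibition and lower numbers for stronger inhibition:
compound 1 `CC(C)c1cc(-c2n[nH]c(=O)n2-c2cccc(C(=O)NCCCCCCC(=O)NO)c2)c(O)cc1O` — 4600 nM
compound 2 `CNC(=O)CCCCCCCNC(=O)c1cccc(-n2c(-c3cc(C(C)C)c(O)cc3O)n[nH]c2=O)c1` — 4600 nM
compound 3 `CC(C)c1cc(-c2n[nH]c(=O)n2-c2ccc(C(=O)NCCCCCCC(=O)NO)cc2)c(O)cc1O` — 4600 nM

Compound 2 stands level with compounds 1 and 3 at the digits shown; its nearest neighbour is compound 1 and its furthest is compound 3, and in neither case does the gap exceed the scatter. For the measured compounds named here, the only single-point step measured, no change at the digits printed from compound 1 to compound 2 (within the scatter), left the read-out unchanged when (methylcarbamoyl)methyl replaced hydroxycarbamoyl six bonds along the chain from an amide-type nitrogen.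

Compound 4 `CC(C)c1cc(-c2n[nH]c(=O)n2-c2cccc(C(=O)NCCCCCC(=O)NO)c2)c(O)cc1O` has not yet been measured. It differs from compound 2 by hydroxycarbamoyl in place of 2-(methylcarbamoyl)ethyl on a saturated chain carbon, five bonds along the chain from an amide-type nitrogen. Going by the values given here, this change returns the hydroxycarbamoyl end group while shortening the chain that carries it; the step from compound 1 to compound 2 bears directly on the end group and was flat, whereas no measured pair speaks to the chain length alone. Compound 4 is therefore expected to sit close to compound 2, with a step of no change at the digits printed from compound 2 to compound 4 (within the scatter) that is not expected to exceed the scatter. The estimate for compound 4 is 4600 nM, within a range of 1800 nM to 12000 nM, the width reflecting the unmeasured chain shortening.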

Compound 4, half-maximal inhibitory concentration: 4600 nM
Compound 4: middle estimate and measured number agree at the digits printed; low and high end bracket the measured number.
By their numbers in this assay, from the lowest: compounds 1, 2, 3 and 4 (each within the scatter of the next).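

In this assay, for the compounds shown here, the length of the chain carrying the hydroxycarbamoyl end group can now be read on its own: hydroxycarbamoyl in place of (hydroxycarbamoyl)methyl, five bonds along the chain from an amide-type nitrogen, gave no change at the digits printed from compound 1 to compound 4 (within the scatter) and so supplied the comparison that the earlier compounds lacked. The exchange of 2-(methylcarbamoyl)ethyl for hydroxycarbamoyl at the same place, which alters the end group and the chain together, gave no change at the digits printed from compound 2 to compound 4 (within the scatter) and added no detectable difference either. Across these three compounds, neither the end group nor this shortening of the chain separated the read-outs, and no independent information is available to account for that.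

The compounds shown leave open whether a longer chain would stay level with these values, or whether a shorter chain than that of compound 4 would do so. They also leave open how a carboxylic acid or an amine would read at the end of the chain in place of hydroxycarbamoyl.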